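This account rests on a few compounds, and the source may have more. Where it says the series, first, only, none or still open, it means among the compounds named here.

Working notes on the series. Among the measured compounds shown here, in a functional assay on A549 cells (Homo sapiens) for antiproliferative activity, read by MTT assay, with a stated time of 48 h (a higher number here means a weaker inhibitor of growth, a lower number a stronger inhibitor of growth), compound 2 (`CCCCN(Cc1ccc(C(=O)NO)cc1)c1ncc(-c2ccc(C)cc2)s1`) gives 4780 nM, the lower of the two numbers so far, while compound 1 (`Cc1ccc(OCCCN(Cc2ccc(C(=O)NO)cc2)c2ncc(-c3ccc(C)cc3)s2)cc1`) gives 32500 nM. The next analogue, compound 3 (`Cc1ccc(-c2cnc(N(CCCOc3ccccc3)Cc3ccc(C(=O)NO)cc3)s2)cc1`), is reached from compound 2 by phenoxy in place of methyl on a saturated chain carbon, three bonds along the chain from a nitrogen on an aromatic ring. In words, this is phenoxy in place of methyl on a saturated chain carbon, three bonds along the chain from a nitrogen on an aromatic ring, or butyl to 3-phenoxypropyl.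

For the measured compounds named here, only one measured step bears on this change: a 6.8-fold lower number from compound 1 to compound 2 (0.83 log units; beyond the scatter), with methyl replacing 4-methylphenoxy at that same place. The change to compound 3 runs close to the reverse of that step, except that it brings in phenoxy and not 4-methylphenoxy. A step of similar, modest size is therefore expected in this assay, towards a higher number and beyond the scatter. Going by the values given here, no measurement yet separates phenoxy from 4-methylphenoxy, and a single step is thin support, so the range stays wide. The expected change is a 5.4-fold higher number from compound 2 to compound 3 (0.74 log units; beyond the scatter). For compound 3 the estimate is 26000 nM, with an expected range of 11000 nM to 60000 nM.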

Compound 3, concentration for 50% growth inhibition: 2530 nM
Compound 3: the middle estimate sits 10-fold (1.01 log units) above what was measured; the whole stated range lies above it.
By their numbers in this assay, from the lowest: compounds 3 and 2 (each within the scatter of the next); then compound 1.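

In this assay, the change from butyl to 3-phenoxypropyl does not by itself move the number as the earlier pair suggested: a 1.9-fold lower number from compound 2 to compound 3 (0.28 log units; within the scatter) and so compound 2 and compound 3 cannot be told apart here. The large difference lies instead in the single methyl at the far end of the chain, with a 13-fold lower number from compound 1 to compound 3 (1.11 log units; beyond the scatter) for hydrogen in place of methyl on an aromatic carbon, so 4-methylphenoxy and phenoxy are not interchangeable at this place in this assay. No measurement shown accounts for this difference.

Still open, going by these compounds, is whether the effect is specific to methyl or would also appear with another group on that aromatic carbon, such as chlorine or methoxy, since a single pair carries the whole observation. On these data alone, it is also open whether a chain ending in an amine or a carboxylic acid, or a longer chain ending in phenoxy, would stay level with compound 2 and compound 3 or move away from them.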